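This account rests on a few compounds, and the source may have more. Where it says the series, first, only, none or still open, it means among the compounds named here.

Measured so far:
compound 1, `CCOC(=O)C1=C(N/N=C(\c2ccc([N+](=O)[O-])cc2)N2CCN(c3ccc(F)cc3)CC2)Nc2[nH]nc(C)c2C1c1ccc(N(C)C)cc1`: 90200 nM
compound 2, `CCOC(=O)C1=C(N/C=N/c2ccc([N+](=O)[O-])cc2)Nc2[nH]nc(C)c2C1c1ccc(N(C)C)cc1`: 50900 nM

In a functional assay on HepG2 cells (Homo sapiens) for inhibition, read by MTT assay, with a stated time of 48 h (on this read-out higher numbers stand for weaker inhibition and lower numbers for stronger inhibition), compound 2 gives 50900 nM, the lower of the two numbers. Going by the values given here, its only neighbour is compound 1, which in this assay gives 90200 nM; the gap between the two lies within the scatter, so neither compound can be set apart from the other on these numbers.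

Compound 3, `CCOC(=O)C1=C(N/C=N/c2ccc(C)cc2)Nc2[nH]nc(C)c2C1c1ccc(N(C)C)cc1`, has not yet been measured in this assay. It differs from compound 2 in one place: methyl in place of nitro on an aromatic carbon. Among the compounds with values here, no pair of measured compounds that differ in a single place is available, so the size of this step cannot be read from any earlier one. The step is expected to be small, a 1.4-fold higher number from compound 2 to compound 3 (0.14 log units; within the scatter), at most slightly toward weaker inhibition and likely within the scatter. Compound 3 is therefore estimated at 70000 nM, with a range from 25000 nM to 200000 nM.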

Compound 3, half-maximal inhibitory concentration: 44400 nM
Estimate against measurement, compound 3: 1.6-fold (0.20 log units) above; low and high end bracket the measured number.
By their numbers in this assay, from the lowest: compounds 3, 2 and 1 (each within the scatter of the next, the first and the last beyond it).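

Replacing nitro with methyl on an aromatic carbon para to a large group gives a 1.1-fold lower number from compound 2 to compound 3 (0.06 log units; within the scatter) in this assay, the only step among the compounds shown that isolates a single place. On this read-out, 4-nitrophenyl and 4-methylphenyl therefore cannot be told apart at this position, even though the change removes both hydrogen-bond acceptors of the nitro group and leaves a single carbon in place of three heavy atoms. No measurement is at hand that would account for this result.

The compounds shown hold only these two groups at this position, so it stays open whether an amine, a carboxylic acid or a longer chain there would also leave the number within the scatter. Also open, from the compounds shown here alone, is whether the same change would give a comparable step in compound 1, which carries a 4-nitrophenyl group too.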